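The source may report more compounds than this note shows. Statements on the series, on what has been measured and on what is new or still open speak of the compounds shown alone.

Measured so far in a physicochemical assay for lipophilicity, read by HPLC, at pH 7.5; a higher number here means a more lipophilic compound, a lower number a more polar compound:
Compound 1 `CC[C@@H](Nc1c(C#N)c(-c2ccc(-c3ccccc3F)cc2)nc2cnccc12)C(N)=O`: 2.7
Compound 2 `CC[C@@H](Nc1c(C#N)c(-c2ccc(-c3ccccc3N(C)C)cc2)nc2cnccc12)C(N)=O`: 3.2
Compound 3 `CC[C@@H](Nc1c(C#N)c(-c2ccc(-c3ccccc3C)cc2)nc2cnccc12)C(N)=O`: 3

Compound 3, at 3, cannot be told apart from either of the other two compounds. The data show a number 0.30 log units higher from compound 1 to compound 3 (within the scatter), and also a number 0.20 log units lower from compound 2 to compound 3 (within the scatter).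

The next compound is compound 4 `CC[C@@H](Nc1c(C#N)c(-c2ccc(-c3cccc(OC)c3)cc2)nc2cnccc12)C(N)=O`, and the change is 3-methoxyphenyl in place of 2-methylphenyl on an aromatic carbon, para to a large group. The three measured steps bear on this exchange only indirectly. Each of them swaps one group for another on an aromatic carbon, among fluoro, dimethylamino and methyl. Among the compounds with values here, no measured compound carries a 3-methoxyphenyl group, so no measured step shows this exchange directly.

The largest measured step is a number 0.50 log units higher from compound 1 to compound 2 (beyond the scatter), which is modest, and the other two stay within the scatter. On that evidence, no step beyond the scatter is expected in this assay, and the data give little ground for a direction. The expected size is a number 0.10 log units lower from compound 3 to compound 4 (within the scatter). Compound 4 is estimated at 2.9, with an expected range from 2.5 to 3.3.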

Compound 4, distribution coefficient: 2.7
Compound 4: middle estimate off by 0.20 log units, on the high side; the range from low to high includes it.
By their numbers in this assay, from the lowest: compounds 1, 4, 3 and 2 (each within the scatter of the next, the first and the last beyond it).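

In this assay, the exchange for 3-methoxyphenyl, the only group shown here that carries oxygen, gives a number 0.30 log units lower from compound 3 to compound 4 (within the scatter) and so does not separate this group from 2-methylphenyl. The same group set against 2-fluorophenyl gives no change at the digits printed from compound 1 to compound 4 (within the scatter) and shows that two aromatic groups differing in both their substituent and its place on the ring can read alike at this position. The comparison with 2-(dimethylamino)phenyl gives a number 0.50 log units lower from compound 2 to compound 4 (beyond the scatter) and adds a second step beyond the scatter to a number 0.50 log units higher from compound 1 to compound 2 (beyond the scatter) so that compound 2 now stands apart from both compound 1 and compound 4, while compound 3 remains within the scatter of all three.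

The compounds shown do not separate the effect of the methoxy group from that of its place on the ring, and they leave open whether a carboxylic acid or an aminomethyl group on this ring would move the number further than any step seen here. No measurement shown gives a reason for any of these steps.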